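Cyclopropyl for Isopropyl on an Anilide Carbonyl

This account rests on a few compounds, and the source may have more. Where it says the series, first, only, none or still open, it means among the compounds named here.

Of the compounds shown here, three sharing one core have been measured in an assay on cells for antagonist activity at transient receptor potential cation channel subfamily V member 1 (Homo sapiens), read by FLIPR and calcium flux, with a stated time of 6 min; a lower number here means a stronger inhibitor, a higher number a weaker inhibitor. Compound 1 `CC1CCN(c2nc(C(F)(F)F)ccc2CNC(=O)C(C)c2cc(O)c(N)c(F)c2)CC1` gives 5.3 nM, compound 2 `CC1CCN(c2nc(C(F)(F)F)ccc2CNC(=O)C(C)c2ccc(Nc3ccc(Cl)cc3)cc2)CC1` gives 66.5 nM, and compound 3 `CC1CCN(c2nc(C(F)(F)F)ccc2CNC(=O)C(C)c2ccc(NC(=O)C(C)C)c(F)c2)CC1` gives 26.4 nM. Among these three numbers compound 3 stands second highest: compound 2 lies beyond the scatter above it, and compound 1 lies beyond the scatter below it. Compound 4 `CC1CCN(c2nc(C(F)(F)F)ccc2CNC(=O)C(C)c2ccc(NC(=O)C3CC3)c(F)c2)CC1` differs from compound 3 in one place: cyclopropyl in place of isopropyl on a carbonyl carbon. Going by the values given here, no measured pair shows this same change, so its effect is not known here. Compound 4 is therefore expected to stay close to compound 3 in this assay, with a step of a 1.1-fold lower number from compound 3 to compound 4 (0.02 log units; within the scatter) that need not exceed the scatter. Compound 4 is estimated at 25 nM, within 10 nM to 60 nM.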

Compound 4, inhibition constant: 20 nM
Compound 4: the middle estimate sits 1.3-fold (0.10 log units) above what was measured, and the stated range covers the measured number.
By their numbers in this assay, from the lowest: compound 1; then compounds 4 and 3 (each within the scatter of the next); then compound 2.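

In this assay cyclopropyl in place of isopropyl on a carbonyl carbon gives a 1.3-fold lower number from compound 3 to compound 4 (0.12 log units; within the scatter) and is the only one-place step among these compounds. At this carbonyl carbon, the open isopropyl and the three-membered ring of the same three carbons are therefore not told apart by this measurement. Nothing available here bears on why the two groups read alike.

From the compounds shown here alone, whether a longer chain, a phenyl ring or an amine on this carbonyl carbon would also stay within the scatter remains open. So does whether the same swap would read alike with the fluorine removed from the aromatic ring.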